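Chloro in Place of Methyl on the Hanging Aryl Ring

The source may report more compounds than this note shows. Statements on the series, on what has been measured and on what is new or still open speak of the compounds shown alone.

The three measured compounds share one core and differ only in the aryl group on the carbon with a double bond to nitrogen. Compound 1 `CCCSc1nc(N/N=C/c2ccccc2F)c2nnn(Cc3ccccc3)c2n1` carries 2-fluorophenyl there; in a functional assay on MCF7 cells (Homo sapiens) for antiproliferative activity, read by MTT assay, with a stated time of 72 h (a lower number here means a stronger inhibitor, a higher number a weaker inhibitor), compound 1 gives only a limit, > 64000 nM. Compound 2 `CCCSc1nc(N/N=C/c2ccccc2Cl)c2nnn(Cc3ccccc3)c2n1` carries 2-chlorophenyl, and in this assay compound 2 gives 13800 nM, so that an at least 4.6-fold lower number from compound 1 to compound 2 (0.66 log units; beyond the scatter). Compound 3 `CCCSc1nc(N/N=C/c2ccc(C)cc2)c2nnn(Cc3ccccc3)c2n1` carries 4-methylphenyl; in this assay compound 3 gives only a limit, > 64000 nM. Compound 3 thus stands at the weak end of what has been measured, sitting at the limit of > 64000 nM in this assay, at which 2 of the 3 values shown sit. The step of an at least 4.6-fold higher number from compound 2 to compound 3 (0.66 log units; beyond the scatter) makes compound 3 the weaker of that pair, while a step that the two limits leave unreadable from compound 1 to compound 3.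

The next compound, compound 4 `CCCSc1nc(N/N=C/c2ccc(Cl)cc2)c2nnn(Cc3ccccc3)c2n1`, differs from compound 3 by chloro in place of methyl on an aromatic carbon. Among the compounds with values here, two measured steps bear on it. The step of an at least 4.6-fold lower number from compound 1 to compound 2 (0.66 log units; beyond the scatter) shows a lower number where chloro stands in place of fluoro, and an at least 4.6-fold higher number from compound 2 to compound 3 (0.66 log units; beyond the scatter) places the methyl-bearing ring at the weak end. The account therefore expects compound 4 to come in with a lower number than compound 3, by a step of an at least 2.1-fold lower number from compound 3 to compound 4 (0.32 log units; beyond the scatter). Compound 4 is expected to give 30000 nM, between 8000 nM and 64000 nM.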

Compound 4, half-maximal inhibitory concentration: > 64000 nM
Compound 4: only a limit was reported (the forecaster's own chance of this, stated with the estimate: 40%); middle value at least 2.1-fold (0.32 log units) away from the limit.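

The chlorine alone does not account for the activity of compound 2: with chloro kept on the ring, 4-chlorophenyl in place of 2-chlorophenyl gives an at least 4.6-fold higher number from compound 2 to compound 4 (0.66 log units; beyond the scatter), so the reading at this position depends on which chlorophenyl group is present. In this assay compound 4 gives > 64000 nM, which is a limit and not a number. The steps to compound 4 from compound 1 and from compound 3 cannot be read, since both ends of each are limits, so chloro in place of methyl shows no measurable change here, and compound 2 remains the only compound with a value rather than a limit, while compound 4 joins the others at the weak end: the limit of > 64000 nM in this assay, at which 3 of the 4 values shown sit.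

The compounds shown leave open how far compounds 1, 3 and 4 lie beyond that limit, and whether 2-methylphenyl or 2-bromophenyl would read like 2-chlorophenyl. They also leave open what an amine or a carboxylic acid on the hanging aryl ring, or a longer chain on the sulfur, would do to the reading.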